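Cyanomethyl to 4-Methylbenzyl: An Expected Cytotoxicity Reading

The compounds below may be only part of what the source reports. "The series", "measured", "known", "first", "only" and "open" are said of these compounds alone.

Compound 1 `CCC1(Cc2ccccc2)OS(=O)(=O)C=C1OCC#N` and compound 2 `CCC1(Cc2ccccc2)OS(=O)(=O)C=C1OCc1ccccc1` share one core and differ only at the saturated chain carbon bound to an oxygen on an unsaturated carbon. In an ADME assay on HEL cells (Homo sapiens) for cytotoxicity, with a stated time of 3 days (on this read-out higher numbers stand for lower toxicity in this test and lower numbers for higher toxicity in this test), compound 1 reaches only the limit of the test, > 200000 nM. In this assay compound 2 gives 200000 nM. The step of a number no higher from compound 1 to compound 2 (the limit leaves the size open) is thus a number no higher, its size left open by the limit of > 200000 nM in this assay, at which 1 of the 2 values shown sits, of compound 1.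

Compound 3 `CCC1(Cc2ccccc2)OS(=O)(=O)C=C1OCc1ccc(C)cc1` differs from compound 1 by 4-methylphenyl in place of cyano on a saturated chain carbon bound to an oxygen on an unsaturated carbon. Among the measured compounds shown here, the only measured step that bears on this change is a number no higher from compound 1 to compound 2 (the limit leaves the size open), in which phenyl entered in place of cyano at the same position; it ran into the limit, so no difference beyond the scatter can be read from it. With 4-methylphenyl entering in the same place, compound 3 is expected to behave alike, and the step of a number no higher from compound 1 to compound 3 (the limit leaves the size open) is expected to stay within the scatter. In this assay compound 3 is accordingly estimated at 200000 nM, with a range from 100000 nM to 400000 nM.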

Compound 3, half-maximal cytotoxic concentration: 41500 nM
For compound 3 the middle estimate is 4.8-fold (0.68 log units) above the measured one; the whole stated range lies above it.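

In this assay, the saturated chain carbon bound to an oxygen on an unsaturated carbon now shows a change that can be read: with 4-methylphenyl in place of cyano, the result is an at least 4.8-fold lower number from compound 1 to compound 3 (0.68 log units; beyond the scatter), whereas the phenyl step had left its size open. The more telling comparison is the one that touches only the aromatic ring, where methyl in place of hydrogen on an aromatic carbon gives a 4.8-fold lower number from compound 2 to compound 3 (0.68 log units; beyond the scatter), which shows that this small addition alone is enough to move the read-out towards higher toxicity in this test. The value of compound 1 is a limit, so the step that starts from it fixes only a least size and not a true one: the limit of > 200000 nM in this assay, at which 1 of the 3 values shown sits.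

As far as these compounds go, whether this shift belongs to the methyl as such, or would also come with a methoxy group, a chlorine atom or an amine on the same aromatic carbon, stays open. The compounds shown also do not tell whether a longer chain between the oxygen and the aromatic ring would keep, lose or deepen the shift.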